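The source may hold more compounds than are shown below. What is called first, only, known or untested is meant among the compounds shown, and "the series" means these compounds.

Compound 2 `N#Cc1ccc(Cn2cc(COc3ccc(Cl)cc3)nn2)cc1` gives 3910 nM in an assay on isolated protein for inhibition of Aromatase (Homo sapiens), read by fluorescence and colorimetric assay, with a stated time of 30 min; on this read-out higher numbers stand for weaker inhibition and lower numbers for stronger inhibition. Among the three measured compounds its number is the smallest, but compound 3 `Cc1ccc(OCc2cn(Cc3ccc(C#N)cc3)nn2)cc1`, with 4170 nM, differs from it by only a 1.1-fold higher number from compound 2 to compound 3 (0.03 log units; within the scatter), so the two cannot be told apart. Compound 1 `N#Cc1ccc(C(c2ccc(C#N)cc2)n2cc(COc3ccc(Cl)cc3)nn2)cc1` gives 16100 nM, and the step of a 4.1-fold lower number from compound 1 to compound 2 (0.61 log units; beyond the scatter) is the only clearly resolved one.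

Compound 4 `Clc1ccc(OCc2cn(Cc3ccccc3)nn2)cc1` changes compound 2 by hydrogen in place of cyano on an aromatic carbon, para to a large group. Going by the values given here, no measured step removes this cyano, and the one change made on an aromatic carbon, from compound 2 to compound 3, stayed within the scatter. Compound 4 is therefore expected to show a 1.4-fold higher number from compound 2 to compound 4 (0.15 log units; within the scatter), an estimate of 5500 nM, within a range of 2000 nM to 15000 nM.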

Compound 4, half-maximal inhibitory concentration: 5040 nM
For compound 4 the middle estimate is 1.1-fold (0.04 log units) above the measured one; low and high end bracket the measured number.
By their numbers in this assay, from the lowest: compounds 2, 3 and 4 (each within the scatter of the next); then compound 1.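

With hydrogen in place of cyano on this aromatic carbon, para to a large group, this assay shows a 1.3-fold higher number from compound 2 to compound 4 (0.11 log units; within the scatter), so compound 2 and compound 4 cannot be told apart. Going by these compounds alone, no earlier step removed this cyano, and this one shows that compound 4 keeps a number of the same size without it. Nothing measured here explains this result. Still open, on these data alone, is whether an amine or a carboxylic acid on this carbon would shift the number beyond the scatter. Also open, as far as these compounds go, is whether removing the cyano from compound 3 would give the same outcome.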